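A few compounds are considered here, and "the series" means these few. Any claim that something is new, unique, unknown or untested is made for them only; others in the source may bear on it.

Measured compounds:
- compound 1, `Cc1ccc(N2C(=O)CS/C2=N/N=C/c2c[nH]c3ccc(Br)cc23)cc1`: 39900 nM
- compound 2, `O=C1CS/C(=N/N=C/c2c[nH]c3ccc(Br)cc23)N1c1cccc2ccccc12`: 29100 nM

Of the compounds shown here, two of the same family have been tested in a functional assay on 786-0 cells (Homo sapiens) for inhibition, read by spectrophotometry and sulforhodamine B assay, with a stated time of 48 h; a higher number here means a weaker inhibitor of growth, a lower number a stronger inhibitor of growth. Compound 1 gives 39900 nM, and compound 2 gives 29100 nM; the gap between these two values lies within the usual scatter of the assay, so the two compounds cannot be told apart on these numbers. Compound 1 thus stands with the higher of the two values, but only by an amount that repeated measurement could erase.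

Compound 3, `Cc1ccc(N2C(=O)CS/C2=N/N=C/c2c[nH]c3ccccc23)cc1`, has not yet been measured. It differs from compound 1 in one place: hydrogen in place of bromo on an aromatic carbon. Among the compounds with values here, no measured pair in the set shows the effect of this change, so there is no direct precedent to lean on. Both measured compounds carry the bromo group and both are weak inhibitors of growth, which gives no hint that the group is dispensable. A modest loss of potency is expected, with a 1.4-fold higher number from compound 1 to compound 3 (0.14 log units; within the scatter) in the direction of a higher number, though a result within the scatter would not be surprising. Compound 3 is estimated at 55000 nM, with a range from 22000 nM to 140000 nM.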

Compound 3, concentration for 50% growth inhibition: 79100 nM
For compound 3 the middle estimate is 1.4-fold (0.16 log units) below the measured one; the measured number falls inside the stated range.
By their numbers in this assay, from the lowest: compounds 2, 1 and 3 (each within the scatter of the next, the first and the last beyond it).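

In this assay, within the data shown here, the first direct reading of hydrogen in place of bromo on this aromatic carbon is a 2.0-fold higher number from compound 1 to compound 3 (0.30 log units; within the scatter), and this step stays within the scatter, so the two compounds cannot be told apart. This single pair therefore neither shows that the bromo group matters at this position nor establishes that it can be given up, since a real difference of this size and ordinary repeat-to-repeat variation would look the same here. No separate measurement bears on why the step has this size.

As far as these compounds go, it remains open whether a different group on this same aromatic carbon, such as chlorine, fluorine, a methoxy group or an amine, would give a number clearly apart from that of compound 1. From the compounds shown here alone, it also remains open whether hydrogen in place of bromo would give a similar step when made on compound 2, where the rest of the molecule differs, or whether the result seen here belongs to the compound 1 structure alone.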